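From 4-Chlorophenyl to Heptyl: A Step Away from the Limit

The source may report more compounds than this note shows. Statements on the series, on what has been measured and on what is new or still open speak of the compounds shown alone.

In a functional assay on HeLa cells (Homo sapiens) for inhibition, read by MTT assay, with a stated time of 48 h (a higher number here means a weaker inhibitor, a lower number a stronger inhibitor), compound 3 `O=[N+]([O-])c1ccc2[nH]cc(C(c3ccc(Cl)cc3)c3c[nH]c4ccc([N+](=O)[O-])cc34)c2c1` gives > 100000 nM, which is a limit of the assay and not a number. Two related compounds do give numbers in this assay: compound 1 `COc1ccc(C(c2c[nH]c3ccc(Br)cc23)c2c[nH]c3ccc(Br)cc23)c(OC)c1` reads 63200 nM, and compound 2 `COc1ccc(OC)c(C(c2c[nH]c3ccc(Br)cc23)c2c[nH]c3ccc(Br)cc23)c1` reads 5100 nM.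

Compound 4 `CCCCCCCC(c1c[nH]c2ccc([N+](=O)[O-])cc12)c1c[nH]c2ccc([N+](=O)[O-])cc12` carries heptyl in place of 4-chlorophenyl on a saturated chain carbon bound to two aromatic carbons. Its ring is thus replaced by an open chain.

For the measured compounds named here, only one measured step touches this place: a 12-fold lower number from compound 1 to compound 2 (1.09 log units; beyond the scatter), with 2,5-dimethoxyphenyl in place of 2,4-dimethoxyphenyl. Going by the values given here, that large step shows that a change here can matter, but it swaps one ring for another, and no measured step swaps a ring for a chain. The expectation is therefore loose, and the result may stay at the limit.

The expected change is an at least 2.0-fold lower number from compound 3 to compound 4 (0.30 log units; that floor lies within the scatter), a modest move towards a lower number. Compound 4 is estimated at 50000 nM, with an expected range of 10000 nM to 150000 nM.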

Compound 4, half-maximal inhibitory concentration: 35000 nM
Compound 4: middle estimate off by 1.4-fold (0.15 log units), on the high side; measured number inside the range.
By their numbers in this assay, from the lowest: compound 2; then compounds 4 and 1 (each within the scatter of the next). At a limit, above all of these: compound 3.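

In this assay, heptyl in place of 4-chlorophenyl on a saturated chain carbon bound to two aromatic carbons gives an at least 2.8-fold lower number from compound 3 to compound 4 (0.45 log units; beyond the scatter) and brings the read-out from a limit to a number. For the compounds shown here, the earlier compounds carry a ring at this place, so this is the first sign that a ring is not required there for a measurable value. The full size of the step cannot be read, because compound 3 stands at a limit and not at a number: the limit of > 100000 nM in this assay, at which 1 of the 4 values shown sits.

Going by these compounds, it remains open whether the gain depends on the length of the chain, which a butyl group or a longer chain such as decyl would test, or on its bare carbon character, which a chain ending in an amine or a carboxylic acid would test. Also open, on these data alone, is whether heptyl would give a similar change on the core of compound 2.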